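Cytotoxicity in the thiazole series: from compound 3 to compound 4

The source may hold more compounds than are shown below. What is called first, only, known or untested is meant among the compounds shown, and "the series" means these compounds.

Measured compounds in an ADME assay on HepG2 2.2.15 cells (Homo sapiens) for cytotoxicity; on this read-out lower numbers stand for higher toxicity in this test and higher numbers for lower toxicity in this test:
- compound 1, `O=C(Nc1ncc(Cc2ccc(F)cc2)s1)c1ccc(Br)cc1`: in this assay compound 1 gives > 50000 nM, which is a limit of the assay and not a number.
- compound 2, `CC(C)(C)OC(=O)Nc1ncc(C(Oc2ccc(OCc3ccccc3)cc2)c2ccc(Cl)cc2)s1`: in this assay compound 2 gives > 50000 nM, again a limit rather than a number.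
- compound 3, `COCCCNc1ncc(C(Oc2ccc3cc(Br)ccc3c2)c2ccc(Cl)cc2)s1`: in this assay compound 3 is recorded as "not toxic" (no number reported), with no number reported.

Compound 3 therefore has no single value to stand on; the other two entries sit at the limit of > 50000 nM in this assay, at which 2 of the 3 values shown sit. Nothing in the set so far gives a measured difference between two compounds, so no size of step can be read from the data.

Compound 4, `O=C(Nc1ncc(C(Oc2ccc3cc(Br)ccc3c2)c2ccc(Cl)cc2)s1)C1CCOCC1`, is the next entry to be measured in this assay. It differs from compound 3 as follows: (oxan-4-yl)carbonyl in place of 3-methoxypropyl on a nitrogen on an aromatic ring. Within the data shown here, with no measured step in hand and all three entries showing no toxicity, no change beyond the usual scatter is expected for this pair. Compound 4 is expected to come out at 50000 nM, with a range of 20000 nM to 100000 nM, most likely reported as a limit only.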

Compound 4, half-maximal cytotoxic concentration: "not toxic" (no number reported)
Nothing numeric was reported for compound 4, and the estimate cannot be compared.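

No step can be read from compound 3 to compound 4: in this assay both are recorded as "not toxic", with no number reported. The compounds shown leave open at what concentration, if any, toxicity appears in this test, and the remaining entries offer only a limit: the limit of > 50000 nM in this assay, at which 2 of the 4 values shown sit.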